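Trading a difluoromethyl for methyl on the ether chain

A few compounds are considered here, and "the series" means these few. Any claim that something is new, unique, unknown or untested is made for them only; others in the source may bear on it.

Compound 1 `O=C(O)Cn1nc(Cc2nc3cc(Cl)c(OCC(F)F)cc3[nH]2)c2ccccc2c1=O` is measured in an ADME assay on the whole organism (plasma, Mus musculus, strain CD1), read by LC-MS, with a stated time of 24 h (a lower number here means a smaller unbound share, a higher number a larger unbound share of the compound), where it gives 0.038. This puts compound 1 second highest of the three numbers: compound 3 `O=C(O)Cc1nn(Cc2cn3cc(OCC4CC4)c(Cl)cc3n2)c2ccccc2c1=O` gives 0.045, close to it, while compound 2 `CCC(C(=O)O)c1nn(Cc2cn3cc(OCC4CC4)c(Cl)cc3n2)c2ccccc2c1=O` gives 0.013. Within the data shown here, the only single-point step measured so far, a 3.5-fold higher number from compound 2 to compound 3 (0.54 log units; beyond the scatter), sits on a different part of the shared core and does not bear directly on the change at hand. Compound 4 `CCOc1cc2[nH]c(Cc3nn(CC(=O)O)c(=O)c4ccccc34)nc2cc1Cl` differs from compound 1 by methyl in place of difluoromethyl on a saturated chain carbon bound to an oxygen on an aromatic ring. Among the measured compounds shown here, with no measured step at this place, no change beyond the scatter is expected, so a 1.1-fold lower number from compound 1 to compound 4 (0.04 log units; within the scatter) is the estimated outcome. Compound 4 is therefore expected to give about 0.035, within 0.018 to 0.07.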

Compound 4, unbound fraction: 0.051
Compound 4: the middle estimate sits 1.5-fold (0.16 log units) below what was measured; measured number inside the range.
By their numbers in this assay, from the lowest: compound 2; then compounds 1, 3 and 4 (each within the scatter of the next).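

At this place on the ether chain, methyl in place of difluoromethyl gives a 1.3-fold higher number from compound 1 to compound 4 (0.13 log units; within the scatter). This first measured step here shows that, in this assay, the two fluorine atoms can be removed without a shift beyond the scatter. Nothing measured here gives a reason for this result.

The compounds shown test only this one swap at this place. A 2,2,2-trifluoroethoxy group, or a longer chain ending in an amine or a hydroxyl, could still give a different number.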